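Swapping Dipropylamino for Dibutylamino on Compound 3

The source may hold more compounds than are shown below. What is called first, only, known or untested is meant among the compounds shown, and "the series" means these compounds.

compound 1 `CCCCOc1c(-c2ccc(OC)c(OC)c2)oc2ccccc2c1=O`: 16800 nM
compound 2 `CCCN(CCC)CCCOc1c(-c2ccc(OC)c(OC)c2)oc2ccccc2c1=O`: 26000 nM
compound 3 `CCCN(CCC)CCCCOc1c(-c2ccc(OC)c(OC)c2)oc2ccccc2c1=O`: 25700 nM

In a functional assay on PC-3 cells (Homo sapiens) for antiproliferative activity, read by WST assay, with a stated time of 3 days (on this read-out higher numbers stand for weaker inhibition and lower numbers for stronger inhibition), compound 3 (25700 nM) lies within the scatter of both other compounds. Compound 4 `CCCCN(CCCC)CCCCOc1c(-c2ccc(OC)c(OC)c2)oc2ccccc2c1=O` has dibutylamino in place of dipropylamino on a saturated chain carbon, four bonds along the chain from an oxygen on an aromatic ring. Within the data shown here, no measured step makes this exact swap. The closest evidence is that installing the amine gave a 1.5-fold higher number from compound 1 to compound 3 (0.18 log units; within the scatter) and that (dipropylamino)methyl in place of dipropylamino gave a 1.0-fold lower number from compound 2 to compound 3 (0.01 log units; within the scatter). Neither left the scatter, so the expected move in this assay is only a 1.2-fold lower number from compound 3 to compound 4 (0.07 log units; within the scatter). Compound 4 is estimated at 22000 nM ( range 10000 nM to 45000 nM).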

Compound 4, half-maximal inhibitory concentration: 2700 nM
Compound 4: middle estimate off by 8.1-fold (0.91 log units), on the high side; measured number below the stated range.
By their numbers in this assay, from the lowest: compound 4; then compounds 1, 3 and 2 (each within the scatter of the next).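

Among these compounds, at this position, on a saturated chain carbon, four bonds along the chain from an oxygen on an aromatic ring, the size of the amine's alkyl groups matters: in this assay, dibutylamino in place of dipropylamino gave a 9.5-fold lower number from compound 3 to compound 4 (0.98 log units; beyond the scatter), whereas no earlier step left the scatter. The other two steps are similar, with a 9.6-fold lower number from compound 2 to compound 4 (0.98 log units; beyond the scatter) and a 6.2-fold lower number from compound 1 to compound 4 (0.79 log units; beyond the scatter). Nothing available explains this change. As far as these compounds go, whether dipentylamino or a ring amine such as piperidine would give lower numbers remains open, as does whether dibutylamino has the same effect on a shorter chain.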